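The source may report more compounds than this note shows. Statements on the series, on what has been measured and on what is new or still open speak of the compounds shown alone.

Compound 1 (`CCOC(=O)c1c(C)cc2cnn(-c3ccc(OC)c(OC)c3)c(=O)c2c1C`) reads >= 50 uM in a functional assay (plasma) for inhibition, with Oryctolagus cuniculus as the target; on this read-out lower numbers stand for an effect already at smaller amounts and higher numbers for an effect only at larger amounts of compound (a limit of the assay, not a number). Compound 2 (`CCOC(=O)c1c(C)cc2cnn(-c3ccc(C)c(Cl)c3)c(=O)c2c1C`) reads >= 50 uM in this assay (again a limit, not a number). Compound 2 therefore has no exact value, and the one further result beside it is a limit too, so the limit of >= 50 uM in this assay, at which 2 of the 2 values shown sit, is all there is to go on. Compound 3 (`CCOC(=O)c1c(C)cc2cnn(-c3ccc([N+](=O)[O-])cc3)c(=O)c2c1C`) differs from compound 2 in one place, with 4-nitrophenyl in place of 3-chloro-4-methylphenyl on an aromatic nitrogen. Among the compounds with values here, no measured pair shows what such a swap does, so no step beyond the scatter is expected. The estimated step of a number no higher from compound 2 to compound 3 (the limit leaves the size open) is expected to stay within the usual scatter of repeated measurements. Compound 3 is expected at 50 uM (estimated range 15 uM to 100 uM).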

Compound 3, concentration for half-maximal effect: >= 50 uM
Compound 3 ended at the assay's limit; the forecaster's own chance of this, stated with the estimate: 70%; the middle value lies on the limit itself.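

Within the data shown here, compound 2 and compound 3 both end at a limit rather than a number in this assay, so no step between them can be read: the limit of >= 50 uM in this assay, at which 3 of the 3 values shown sit. The compounds shown leave open what exact value any of them has and what 4-nitrophenyl in place of 3-chloro-4-methylphenyl does.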